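The source may report more compounds than this note shows. Statements on the series, on what has been measured and on what is new or still open speak of the compounds shown alone.

Compound 1 `COc1ccccc1C(=O)NC(=O)Nc1ccc(-c2ccccn2)c(C(F)(F)F)c1` carries a pyridin-2-yl group on the shared core, and in an ADME assay on LLC-PK1 cells (Sus scrofa) for permeability (on this read-out lower numbers stand for lower permeability and higher numbers for higher permeability), compound 1 gives 7.4 10^-6 cm/s. Compound 2 `COc1ccccc1C(=O)NC(=O)Nc1ccc(-c2ccccc2)c(C(F)(F)F)c1` carries a phenyl in that place instead. For compound 2 the this assay reports only a limit, < 1 10^-6 cm/s, not a measured number (the limit of < 1 10^-6 cm/s in this assay, at which 1 of the 2 values shown sits). The exchange of pyridin-2-yl for phenyl therefore gave an at least 7.4-fold lower number from compound 1 to compound 2 (0.86 log units; beyond the scatter), and where compound 2 truly stands is known only as sitting at that limit.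

Compound 3 `COc1ccccc1C(=O)NC(=O)Nc1ccc(C(C)C)c(C(F)(F)F)c1` differs from compound 2 by isopropyl in place of phenyl on an aromatic carbon. Within the data shown here, no measured step here swaps phenyl for isopropyl; the one measured step touches the same place on the core but a different pair of groups, so it gives only weak guidance on size or direction. Because compound 2 shows only the limit < 1 10^-6 cm/s in this assay, the starting point itself is uncertain. Compound 3 is expected to give about 1.5 10^-6 cm/s in this assay, with a likely range from 0.3 10^-6 cm/s to 8 10^-6 cm/s. That estimate means an expected at least 1.5-fold higher number from compound 2 to compound 3 (0.17 log units; that floor lies within the scatter), while a reading at the limit again would not surprise.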

Compound 3, apparent permeability in the LLC-PK1 assay: 2.1 10^-6 cm/s
Compound 3: the middle estimate sits 1.4-fold (0.15 log units) below what was measured; the measured number falls inside the stated range.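

With isopropyl, which has no ring, in place of the two six-membered aromatic rings seen so far, the LLC-PK1 assay shows an at least 2.1-fold higher number from compound 2 to compound 3 (0.32 log units; beyond the scatter) and a 3.5-fold lower number from compound 1 to compound 3 (0.55 log units; beyond the scatter), so compound 3 falls between the other two, and the first of these steps gives only a floor for its size: the limit of < 1 10^-6 cm/s in the LLC-PK1 assay, at which 1 of the 3 values shown sits. In a physicochemical assay for solubility, in phosphate buffer, at pH 7.4 (on this read-out higher numbers stand for higher solubility and lower numbers for lower solubility), compound 2 gives < 1 ug/mL, which is a limit and not a number. In the physicochemical assay, compound 3 gives < 1 ug/mL, again a limit, so the step between these two compounds cannot be read, because both sit at the same limit: the limit of < 1 ug/mL in the physicochemical assay, at which 2 of the 2 values shown sit.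

The compounds shown leave open whether an amine or a carboxylic acid on this aromatic carbon would give a measured number rather than a limit in the physicochemical assay. They also leave open whether a longer chain in place of isopropyl would raise or lower the reading in the LLC-PK1 assay, and how far compound 2 truly lies under its limit there.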